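Swapping Methyl for Methoxy in a Growth Inhibitor

This account rests on a few compounds, and the source may have more. Where it says the series, first, only, none or still open, it means among the compounds named here.

Within the data shown here, in a functional assay on MCF7 cells (Homo sapiens) for inhibition, read by MTT assay (a higher number here means a weaker inhibitor of growth, a lower number a stronger inhibitor of growth), compound 2 (`COc1cc2oc(-c3cccc(NC(=O)c4ccc(C)cc4)c3)cc(=O)c2c(OC)c1OC`) gives 8320 nM, the lower of the two numbers so far, while compound 1 (`COc1cc2oc(-c3cccc(NC(=O)c4cccc(C#N)c4)c3)cc(=O)c2c(OC)c1OC`) gives 41700 nM. Compound 3 (`COc1ccc(C(=O)Nc2cccc(-c3cc(=O)c4c(OC)c(OC)c(OC)cc4o3)c2)cc1`) has methoxy in place of methyl on an aromatic carbon, para to a large group: methoxy in place of methyl on an aromatic carbon. Among the measured compounds shown here, only one measured step bears on this, a 5.0-fold lower number from compound 1 to compound 2 (0.70 log units; beyond the scatter), and it exchanged a whole substituted phenyl group, so it is a loose guide. A much smaller change is expected here, a 1.2-fold higher number from compound 2 to compound 3 (0.08 log units; within the scatter), with no shift beyond the scatter. Compound 3 is estimated at 10000 nM, with a range of 3500 nM to 30000 nM.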

Compound 3, concentration for 50% growth inhibition: 6870 nM
Beside the measured number, compound 3's estimate is 1.5-fold (0.16 log units) above it, and the stated range covers the measured number.
By their numbers in this assay, from the lowest: compounds 3 and 2 (each within the scatter of the next); then compound 1.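

In this assay, swapping methyl for methoxy at this position gives a 1.2-fold lower number from compound 2 to compound 3 (0.08 log units; within the scatter), so this single-group change leaves the growth inhibition indistinguishable. Compound 3 also gives a 6.1-fold lower number from compound 1 to compound 3 (0.78 log units; beyond the scatter), so 4-methoxyphenyl, like 4-methylphenyl, has a clear edge over 3-cyanophenyl. No available evidence bears on the reason for these results.

As far as these compounds go, whether an amine or a carboxylic acid at this position would also leave the number unmoved remains open. So does the effect of a longer chain, such as ethoxy.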